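The compounds below may be only part of what the source reports. "The series", "measured", "known", "first", "only" and "open" are said of these compounds alone.

Of the compounds shown here, three that share one core have been measured in a functional assay on PC-3 cells (Homo sapiens) for cytotoxicity, read by MTT assay, with a stated time of 48 h; on this read-out lower numbers stand for stronger inhibition and higher numbers for weaker inhibition. Compound 1 `COc1cc(-c2nnc3n2NC(c2ccco2)C(C(=O)c2ccc(F)c(F)c2)S3)cc(OC)c1OC` gives 36000 nM. Compound 2 `COc1cc(-c2nnc3n2NC(c2ccco2)C(C(=O)C2CC2)S3)cc(OC)c1OC` gives 95200 nM. Compound 3 `COc1cc(-c2nnc3n2NC(c2ccco2)C(C(=O)c2cccs2)S3)cc(OC)c1OC` gives 46200 nM. Among these three numbers compound 3 stands second highest; its number and that of compound 1 lie within the scatter of each other, while compound 2 lies beyond it, with a 2.1-fold lower number from compound 2 to compound 3 (0.31 log units; beyond the scatter).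

Compound 4 `COc1cc(-c2nnc3n2NC(c2ccco2)C(C(=O)c2ccccc2F)S3)cc(OC)c1OC` has not been measured. It differs from compound 3 in one place: 2-fluorophenyl in place of thiophen-2-yl on a carbonyl carbon. Of the measured steps, the one that bears most on this change is a 1.3-fold higher number from compound 1 to compound 3 (0.11 log units; within the scatter), which put thiophen-2-yl in place of 3,4-difluorophenyl on a carbonyl carbon and kept the number within the scatter. The remaining steps, a 2.6-fold higher number from compound 1 to compound 2 (0.42 log units; beyond the scatter) and a 2.1-fold lower number from compound 2 to compound 3 (0.31 log units; beyond the scatter), concern cyclopropyl and show only that cyclopropyl gives a higher number than either aromatic group in this set. Since compound 1 gives 36000 nM with 3,4-difluorophenyl in this place, compound 4 with 2-fluorophenyl is expected to give a number close to that of compound 3. For compound 4 the expected step is a 1.2-fold lower number from compound 3 to compound 4 (0.08 log units; within the scatter), which is expected to stay within the scatter. The estimate for compound 4 is therefore 38000 nM, with a range from 15000 nM to 95000 nM.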

Compound 4, half-maximal inhibitory concentration: > 100000 nM
Compound 4: only a limit was reported; the forecaster's own chance of this, stated with the estimate: 10%; middle value at least 2.6-fold (0.42 log units) away from the limit.
By their numbers in this assay, from the lowest: compounds 1 and 3 (each within the scatter of the next); then compound 2. At a limit, above all of these: compound 4.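

In this assay, compound 4 yields a limit of the assay and not a number: the limit of > 100000 nM in this assay, at which 1 of the 4 values shown sits.

Thiophen-2-yl and 3,4-difluorophenyl on this carbonyl carbon had stayed within the scatter of each other, yet 2-fluorophenyl brings an at least 2.1-fold higher number from compound 3 to compound 4 (0.33 log units; beyond the scatter) and an at least 2.7-fold higher number from compound 1 to compound 4 (0.44 log units; beyond the scatter), so an aromatic ring at this place is not enough to keep the number low. The step from cyclopropyl, an at least 1.0-fold higher number from compound 2 to compound 4 (0.02 log units; that floor lies within the scatter), has a floor within the scatter, so 2-fluorophenyl cannot be set apart from cyclopropyl, and compound 4 goes against the earlier picture in which the aromatic groups gave lower numbers than cyclopropyl.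

The compounds shown do not tell whether an unsubstituted phenyl or a 3-fluorophenyl on this carbonyl carbon would fall with the lower numbers or with 2-fluorophenyl, so the part played by the fluorine and by its place on the ring remains open. Also open, going by these compounds, is how a group of another kind, such as an aminomethyl group or a carboxylic acid carried on the ring, would behave in this position.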